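The compounds below may be only part of what the source reports. "The series", "measured", "known", "first", "only" and "open" are said of these compounds alone.

Measured compounds:
- compound 1 `O=C1Nc2ccc([N+](=O)[O-])cc2/C1=N/NC(=S)N1CCN(c2ccccc2)CC1`: 17900 nM
- compound 2 `Cc1ccc(N2CCN(C(=S)N/N=C3\C(=O)Nc4ccc(Cl)cc43)CC2)c(C)c1`: 3590 nM

In a functional assay on A549 cells (Homo sapiens) for inhibition, read by MTT assay, with a stated time of 72 h (a higher number here means a weaker inhibitor, a lower number a stronger inhibitor), compound 1 gives 17900 nM. In this assay compound 2 gives 3590 nM, the lowest of the two numbers; the gap to compound 1 lies beyond the usual scatter. For the measured compounds named here, compound 1 and compound 2 differ in more than one place, so the two values show only that compound 2 is the stronger inhibitor of the pair, not which change accounts for it.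

Compound 3 `O=C1Nc2ccc(Cl)cc2/C1=N/NC(=S)N1CCN(c2ccccc2F)CC1` is yet to be measured in this assay. It differs from compound 2 in one place: 2-fluorophenyl in place of 2,4-dimethylphenyl on an amine nitrogen in a ring. Going by the values given here, no measured pair isolates a change of this kind, so the direction is open. Compound 1, which carries a plain phenyl at the same ring nitrogen, gives the higher number, but it also carries a nitro group in place of chlorine, so it is no clean guide. The expectation is a modest move toward a higher number, estimated as a 1.8-fold higher number from compound 2 to compound 3 (0.26 log units; within the scatter), with a range that still covers no change beyond the scatter.

Compound 3 is therefore estimated at 6500 nM in this assay, expected between 2500 nM and 17000 nM.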

Compound 3, half-maximal inhibitory concentration: 10500 nM
For compound 3 the middle estimate is 1.6-fold (0.21 log units) below the measured one, and the stated range covers the measured number.
By their numbers in this assay, from the lowest: compound 2; then compounds 3 and 1 (each within the scatter of the next).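

In this assay, for the compounds shown here, exchanging 2,4-dimethylphenyl for 2-fluorophenyl on the amine nitrogen in the six-membered ring, with the rest of the molecule unchanged, gives a 2.9-fold higher number from compound 2 to compound 3 (0.47 log units; beyond the scatter) and is the first reading that isolates a single change. The aryl group at this position therefore matters on its own: the step lies beyond the usual scatter, and within this pair the 2,4-dimethylphenyl compound is the stronger inhibitor, although the step is modest in size. Nothing at hand explains the step, which stands as an observation without an assigned cause.

The change removes two methyl groups and introduces a fluorine in one move, so the pair cannot show which part of the exchange carries the step, and a single-substituent group such as 2-methylphenyl or 2-methoxyphenyl on the same nitrogen would be needed to separate them. From the compounds shown here alone, it also remains open whether the same exchange gives a step of similar direction and size on a core bearing a nitro group in place of chlorine.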